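A Second Fluorine on the Benzyl Group

A few compounds are considered here, and "the series" means these few. Any claim that something is new, unique, unknown or untested is made for them only; others in the source may bear on it.

Three measured compounds share one core and differ only in what sits on the benzyl group. Compound 1 `CC(C)(C)c1cc(/C=C/C(=O)NCCC2CCN(Cc3ccccc3)CC2)cc(C(C)(C)C)c1O` carries nothing extra there, compound 2 `Cc1ccc(CN2CCC(CCNC(=O)/C=C/c3cc(C(C)(C)C)c(O)c(C(C)(C)C)c3)CC2)cc1` carries a methyl, and compound 3 `CC(C)(C)c1cc(/C=C/C(=O)NCCC2CCN(Cc3ccc(F)cc3)CC2)cc(C(C)(C)C)c1O` carries a fluoro. In an assay on isolated protein for inhibition of Amine oxidase [flavin-containing] B (Homo sapiens), read by fluorescence, with stated times of 15 min and 20 min (on this read-out lower numbers stand for stronger inhibition and higher numbers for weaker inhibition), compound 1 gives 8500 nM, compound 2 gives 8900 nM and compound 3 gives 11100 nM. Of the three numbers, that of compound 3 is the highest, yet the steps of a 1.3-fold higher number from compound 1 to compound 3 (0.12 log units; within the scatter) and a 1.2-fold higher number from compound 2 to compound 3 (0.10 log units; within the scatter) both fall within the scatter, as does a 1.0-fold higher number from compound 1 to compound 2 (0.02 log units; within the scatter), so the three compounds cannot be told apart on these data.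

Compound 4 `CC(C)(C)c1cc(/C=C/C(=O)NCCC2CCN(Cc3ccc(F)cc3F)CC2)cc(C(C)(C)C)c1O` differs from compound 3 by fluoro in place of hydrogen on an aromatic carbon. Among the compounds with values here, two measured steps bear on this change: the first fluoro entering the ring in a 1.3-fold higher number from compound 1 to compound 3 (0.12 log units; within the scatter), and fluoro replacing methyl in a 1.2-fold higher number from compound 2 to compound 3 (0.10 log units; within the scatter). Both were small. Given those two steps, compound 4 is expected to show a 1.1-fold higher number from compound 3 to compound 4 (0.03 log units; within the scatter), that is, no shift beyond the scatter. Compound 4 is therefore estimated to give about 12000 nM in this assay, with a plausible range from 6000 nM to 24000 nM.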

Compound 4, half-maximal inhibitory concentration: 12500 nM
Compound 4: middle estimate off by 1.0-fold (0.02 log units), on the low side; the range from low to high includes it.
By their numbers in this assay, from the lowest: compounds 1, 2, 3 and 4 (each within the scatter of the next).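

Placing a second fluoro on the aromatic carbon ortho to a large group, and meta to the first fluoro, tests a ring position that the earlier compounds left untouched, and in this assay the result is a 1.1-fold higher number from compound 3 to compound 4 (0.05 log units; within the scatter) so this position accepts the extra fluoro without a shift that can be told from the scatter. The wider comparisons across the benzyl group tell the same story, with a 1.5-fold higher number from compound 1 to compound 4 (0.17 log units; within the scatter) for the 2,4-difluorophenyl group against plain phenyl and a 1.4-fold higher number from compound 2 to compound 4 (0.15 log units; within the scatter) against 4-methylphenyl, so even two fluoro groups together do not separate compound 4 from compound 1 or compound 2 on this read-out. Nothing in the available data speaks to why these numbers lie so close together.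

On these data alone, whether a chloro, a methoxy or an amine on this same ring carbon would move the number beyond the scatter remains open. As far as these compounds go, all four compounds also share the same core, so it is equally open how a longer chain between the amide and the saturated ring, or a carboxylic acid on the benzyl ring, would fare in this assay on this enzyme.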